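The source may hold more compounds than are shown below. What is called first, only, known or untested is meant among the compounds shown, and "the series" means these compounds.

Measured so far:
compound 1 `C=CCNC(=S)NCCCCn1nc(-c2ccccc2)ccc1=O` — 27.1%
compound 2 `CN(C)/C(=N/CCCn1nc(-c2ccccc2)ccc1=O)NC#N` — 72.2%

In a functional assay on the whole organism with Rattus norvegicus as the target, at a dose of 100 mg/kg (a lower number here means less inhibition, a higher number more inhibition at the dose given (going by the name of the read-out)), compound 2 stands highest of the two numbers, with compound 1 the nearest; the step of a number 45.1 percentage points higher from compound 1 to compound 2 (beyond the scatter) lies beyond the scatter and exchanges the whole side chain.

Compound 3 `C#CCN/C(=N/CCCn1nc(-c2ccccc2)ccc1=O)NC#N` keeps the side chain of compound 2 and carries only (propargylamino in place of dimethylamino on a carbon with a double bond to nitrogen). For the measured compounds named here, no measured step changes this group alone; the one step known, a number 45.1 percentage points higher from compound 1 to compound 2 (beyond the scatter), swaps a far larger fragment and bears on it only loosely. A step within the scatter is expected, a number 10.2 percentage points lower from compound 2 to compound 3 (beyond the scatter), so compound 3 is estimated at 62%, range 35% to 85%.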

Compound 3, a percentage reported as inhibition, in the whole organism at one dose (the size of the read-out at that dose, not a potency): -11.8%
Compound 3: the middle estimate sits 73.8 percentage points above what was measured; the measured number lies below the stated range.
By their numbers in this assay, from the lowest: compound 3; then compound 1; then compound 2.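

In this assay, with the side chain held constant, exchanging dimethylamino for propargylamino on a carbon with a double bond to nitrogen gives a number 84 percentage points lower from compound 2 to compound 3 (beyond the scatter). This single place can therefore shift the read-out strongly on its own, which the earlier whole-chain exchange could not show, and compound 3 reads -11.8%, a negative number. No measurement available explains the size of this step.

Still open, on these data alone, is whether the loss follows the triple bond or the hydrogen-bond donor that enters with propargylamino. An allylamino or a methylamino group at this place would help separate the two.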